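Second fluoro on the core of compound 1

The compounds below may be only part of what the source reports. "The series", "measured", "known", "first", "only" and "open" are said of these compounds alone.

Compound 1 `O=C(O)CC(Cc1nc2cc(F)ccc2[nH]1)c1ccc(Cl)cc1` gives 30% in an assay on isolated protein for inhibition of protein kinase C zeta type (Homo sapiens), read by 33P incorporation, tested at 200 uM (a lower number here means a weaker effect, a higher number a stronger effect of the compound at the concentration tested), the higher of the two numbers recorded so far. Its nearest neighbour is compound 2 `CCc1ccc2[nH]c(CC(CC(=O)O)c3ccc(Cl)cc3)nc2c1`, which gives 0% in this assay; the change from one to the other, ethyl in place of fluoro on an aromatic carbon, brought a number 30 percentage points lower from compound 1 to compound 2 (beyond the scatter).

Compound 3 `O=C(O)CC(Cc1nc2cc(F)c(F)cc2[nH]1)c1ccc(Cl)cc1` has not been measured. It differs from compound 1 by fluoro in place of hydrogen on an aromatic carbon, the fluoro of compound 1 being kept and a second one added on the same six-membered ring.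

For the measured compounds named here, only one measured step exists, and it replaces the fluoro of compound 1 rather than adding beside it; it shows that a change on this ring can move the read-out well beyond the scatter, but it does not tell in which direction a second fluoro would act. A single added fluorine is a small change, so no step beyond the scatter is expected in this assay, with a wide range to allow for either direction. Compound 3 is therefore estimated at 28%, within a range from 5% to 50%. The expected step is a number 2 percentage points lower from compound 1 to compound 3 (within the scatter).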

Compound 3, a percentage reported as inhibition, at one concentration (the size of the read-out at that concentration, not a potency): 50%
The estimate for compound 3 lay 22 percentage points below the measured number, and the stated range covers the measured number.
By their numbers in this assay, from the lowest: compound 2; then compound 1; then compound 3.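

Adding a second fluoro, ortho to the fluoro group kept from compound 1, gives in this assay a number 20 percentage points higher from compound 1 to compound 3 (beyond the scatter) and so shows that this aromatic carbon of the shared core can also move the read-out beyond the scatter. The earlier step, a number 30 percentage points lower from compound 1 to compound 2 (beyond the scatter), came from replacing the existing fluoro, whereas this one comes from adding a substituent while keeping it, and it is the first change shown to raise the number. No available measurement bears on the reason for this rise.

On these data alone, it remains open whether the rise is specific to fluoro or would also occur with methoxy or trifluoromethyl on the same aromatic carbon, and whether it depends on the fluoro kept from compound 1. The carboxylic acid and the chlorophenyl group are shared by all three compounds, so the series also leaves open how an amide in place of the acid would alter the read-out, or whether the gain on the core would carry over to such a compound.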